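Replacing the 4-fluorophenyl group on the shared core

The source may report more compounds than this note shows. Statements on the series, on what has been measured and on what is new or still open speak of the compounds shown alone.

Measured so far in a functional assay on OVCAR-8 cells (Homo sapiens) for antiproliferative activity, read by MTT assay, with a stated time of 72 h; on this read-out higher numbers stand for weaker inhibition and lower numbers for stronger inhibition
- compound 1 `O=C(Nc1cccc(F)c1)c1cc(=O)[nH]c2cc(Br)ccc12` gives 5800 nM
- compound 2 `O=C(Nc1cc(F)cc(F)c1)c1cc(=O)[nH]c2cc(Br)ccc12` gives 12100 nM
- compound 3 `O=C(Nc1cccc(F)c1)c1cc(=O)[nH]c2cc(-c3ccc(F)cc3)ccc12` gives 22300 nM

Compound 3 lies within the scatter of compound 2, and both carry higher numbers than compound 1. The next structure, compound 4 `O=C(Nc1cccc(F)c1)c1cc(=O)[nH]c2cc(C3=CCOCC3)ccc12`, differs from compound 3 as follows: a group of 6 heavy atoms (5 carbon, 1 oxygen; one six-membered non-aromatic ring with 1 hetero atom) in place of a group of 7 heavy atoms (6 carbon, 1 fluorine; one six-membered aromatic ring of carbon only), on an aromatic carbon. A six-membered non-aromatic ring with 1 hetero atom thus enters in place of 4-fluorophenyl.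

The closest evidence is a change at the same aromatic carbon, a 3.8-fold higher number from compound 1 to compound 3 (0.58 log units; beyond the scatter), a modest step beyond the scatter. The other measured step, a 2.1-fold higher number from compound 1 to compound 2 (0.32 log units; beyond the scatter), is also modest but concerns a fluoro elsewhere in the molecule and bears on this change only weakly. No non-aromatic ring has been measured at this carbon, so the direction is uncertain. A small move towards compound 1 is expected, probably within the scatter. The expected step is a 1.6-fold lower number from compound 3 to compound 4 (0.20 log units; within the scatter). For compound 4 the estimated value is 14000 nM, with an expected range of 5500 nM to 35000 nM.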

Compound 4, half-maximal inhibitory concentration: 21800 nM
Compound 4: the middle estimate sits 1.6-fold (0.19 log units) below what was measured; measured number inside the range.
By their numbers in this assay, from the lowest: compound 1; then compounds 2, 4 and 3 (each within the scatter of the next).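

In this assay, the non-aromatic ring with one hetero atom and 4-fluorophenyl are not separated at this aromatic carbon: a 1.0-fold lower number from compound 3 to compound 4 (0.01 log units; within the scatter). The loss of the aromatic ring and the fluorine, and the entry of a hydrogen-bond acceptor, therefore leave no readable mark here. Two different rings in place of bromo now give steps of like size, a 3.8-fold higher number from compound 1 to compound 3 (0.58 log units; beyond the scatter) and a 3.8-fold higher number from compound 1 to compound 4 (0.58 log units; beyond the scatter), so among these three compounds only the bromo compound stands apart, and nothing given here explains this.

From the compounds shown here alone, it remains open whether a group without a ring at this carbon, such as an amine, a carboxylic acid or a longer alkyl chain, would stay with compound 3 and compound 4 or return towards compound 1. Also unresolved is whether a saturated ring such as morpholine would behave like the ring in compound 4.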